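Extending a Ketone Side Chain: Isopropyl to Isobutyl

The source may report more compounds than this note shows. Statements on the series, on what has been measured and on what is new or still open speak of the compounds shown alone.

Measured compounds:
Compound 1 `Cc1c(OCCCCOc2ccccc2C(=O)O)ccc(C(=O)CC2CCCC2)c1O`: 32.9%
Compound 2 `CCCC(=O)c1ccc(OCCCCOc2ccc(F)c(C(=O)O)c2)c(C)c1O`: 56.9%
Compound 3 `COc1ccc(C(=O)O)cc1OCCCCOc1ccc(C(=O)C(C)C)c(O)c1C`: 59.9%

These three compounds share a core and were tested in an assay on HEK293 cells for positive allosteric modulation of metabotropic glutamate receptor 3 (Rattus norvegicus), read by thallium flux, with a stated time of 2.5 min; a higher number here means a larger maximal response, a lower number a smaller maximal response. In that assay compound 3 gives 59.9%, the top figure of the three as written. Its gap to compound 2, which gives 56.9%, lies within the scatter, so the two cannot be told apart. Compound 1, with 32.9%, lies beyond the scatter below compound 3.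

Compound 4 `COc1ccc(C(=O)O)cc1OCCCCOc1ccc(C(=O)CC(C)C)c(O)c1C` has not yet been measured. It differs from compound 3 in one place: isobutyl in place of isopropyl on a carbonyl carbon. Within the data shown here, no measured pair of compounds shows what such a change does, so there is no step to lean on. Since the change only lengthens a small alkyl group on the carbonyl carbon and adds no donor, acceptor, ring or charge, the expected step of a number 4.9 percentage points lower from compound 3 to compound 4 (within the scatter) is small, with no change expected beyond the scatter. Compound 4 is therefore estimated at 55%, within a range from 40% to 70%.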

Compound 4, largest response reached (reported as percent of maximum), in percent of the reference or control that the assay uses: 100%
For compound 4 the middle estimate is 45 percentage points below the measured one; measured number above the stated range.
By their numbers in this assay, from the lowest: compound 1; then compounds 2 and 3 (each within the scatter of the next); then compound 4.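

In this assay, isobutyl in place of isopropyl on a carbonyl carbon gives a number 40.1 percentage points higher from compound 3 to compound 4 (beyond the scatter) and shows that this place on the molecule is highly sensitive to the shape of a small alkyl group. Among these compounds, the change brings in no ring, hydrogen-bond donor, hydrogen-bond acceptor or net charge, yet it still moves the maximal response well beyond the scatter, something no earlier pair could show. Nothing given here accounts for the size of this step.

Going by these compounds, it remains open whether a longer chain, such as isopentyl, or an amine on the same carbonyl carbon would keep, raise or lose this response. Also open, on these data alone, is whether the same change would act alike on other compounds, as compound 1 and compound 2 differ from compound 4 in more than one place.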